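The compounds below may be only part of what the source reports. "The series", "measured", "known", "first", "only" and "open" are said of these compounds alone.

In an ADME assay on HepG2 cells (Homo sapiens) for cytotoxicity, with a stated time of 72 h (a higher number here means that more compound is needed for the effect, a lower number that less compound is needed), compound 1 `O=C(Nc1cccc(-c2nc3ccccc3s2)c1)c1cc([N+](=O)[O-])ccc1Cl` gives > 27000 nM, which is a limit of the assay and not a number. Compound 2 `Cc1ccc(-c2nc3ccccc3s2)cc1NC(=O)c1cc([N+](=O)[O-])c(N(C)C)cc1Cl` gives > 25000 nM in this assay, again a limit. Compound 3 `COC(=O)C1CCN(c2cc(Cl)c(C(=O)Nc3cc(-c4nc5ccccc5s4)ccc3C)cc2[N+](=O)[O-])CC1` likewise gives > 25000 nM in this assay, a limit, so compound 3 stands among values of which all three are limits, two at the limit of > 25000 nM in this assay, at which 2 of the 3 values shown sit, and one at the limit of > 27000 nM in this assay, at which 1 of the 3 values shown sits. Within the data shown here, the one measured step in this assay, a step that the two limits leave unreadable from compound 2 to compound 3, is therefore unreadable, and it bears on the present change only in showing that a larger or smaller substituent at this position has not yet produced a readable number. Compound 4 `Cc1ccc(-c2nc3ccccc3s2)cc1NC(=O)c1cc([N+](=O)[O-])ccc1Cl` differs from compound 3 by hydrogen in place of 4-(methoxycarbonyl)piperidin-1-yl on an aromatic carbon. With no readable step to lean on, the expected step from compound 3 to compound 4 in this assay is a step that the limit leaves unreadable from compound 3 to compound 4, that is, none beyond the scatter. Compound 4 is therefore expected to show 30000 nM in this assay, within a range of 10000 nM to 100000 nM, and most probably the assay will again report only a limit.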

Compound 4, half-maximal effective concentration: > 14000 nM
Compound 4 gave a limit, no number; the forecaster's own chance of this, stated with the estimate: 80%; the middle value does not contradict the limit.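

In this assay, among these compounds, compound 4 gives only a limit, as do compound 1, compound 2 and compound 3, so no step from any of them to compound 4 can be read. The compounds shown leave open whether any change to the shared core would give a number rather than a limit in this assay.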